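This account rests on a few compounds, and the source may have more. Where it says the series, first, only, none or still open, it means among the compounds named here.

Working notes on the series. In an ADME assay on cells (Hepatocyte, Homo sapiens) for metabolic stability, with a stated time of 30 min (a higher number here means that more of the compound is left, a lower number that less of the compound is left), compound 1 `O=C(OC1CCC(CN2CCN(c3cc(=O)c4cc(C(F)(F)F)cc([N+](=O)[O-])c4s3)CC2)CC1)c1cccs1` gives 2.2%. Compound 2 `O=C(OC1CCC(CN2CCN(c3cc(=O)c4cc(C(F)(F)F)cc([N+](=O)[O-])c4s3)CC2)CC1)c1ccncc1`, bearing pyridin-4-yl in place of thiophen-2-yl on a carbonyl carbon, gives 1% in this assay; the step of a number 1.2 percentage points lower from compound 1 to compound 2 (within the scatter) leaves the two compounds within the scatter of one another, both with very little remaining. Compound 3 `O=C(NC1CCC(CN2CCN(c3cc(=O)c4cc(C(F)(F)F)cc([N+](=O)[O-])c4s3)CC2)CC1)c1ccccc1` is the next member. Its change from compound 2 is benzamido in place of ((pyridin-4-yl)carbonyl)oxy on a saturated ring carbon. Within the data shown here, only one measured step exists, from compound 1 to compound 2; it swapped the aromatic ring on the carbonyl carbon and stayed within the scatter, and it bears only partly on the present change, which replaces the whole ((pyridin-4-yl)carbonyl)oxy group rather than its ring alone. Among the measured compounds shown here, no measured step covers the benzamido link. A step of a number 3 percentage points higher from compound 2 to compound 3 (within the scatter) in this assay is expected, none beyond the scatter. Compound 3 is estimated at 4%, with a range from 0% to 18%.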

Compound 3, percent of the compound remaining: 92.9%
For compound 3 the middle estimate is 88.9 percentage points below the measured one; the measured number lies above the stated range.
By their numbers in this assay, from the lowest: compounds 2 and 1 (each within the scatter of the next); then compound 3.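

The ring swap on the carbonyl carbon stayed within the scatter, but at this saturated ring carbon the benzamido group in this assay gives a number 91.9 percentage points higher from compound 2 to compound 3 (beyond the scatter) and a number 90.7 percentage points higher from compound 1 to compound 3 (beyond the scatter) on the same shared core. This shows that the number at this position can move far beyond the scatter, and that the change reaching it alters more than the aromatic ring alone, since the carbonyl-oxy link gives way to the amide link and the ring becomes one of carbon only. Nothing at hand gives a reason for the size of these steps.

The compounds shown do not separate the effect of the link from that of the ring, which a pyridin-4-yl or thiophen-2-yl amide would do. From the compounds shown here alone, whether a simple amine or a longer chain between the carbonyl and the saturated ring behaves like benzamido remains open.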